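Swapping Acetyl for 2-methylprop-2-en-1-yl: A Tolerance Estimate

The source may report more compounds than this note shows. Statements on the series, on what has been measured and on what is new or still open speak of the compounds shown alone.

Measured in an ADME assay on Vero 76 cells (Chlorocebus sabaeus) for cytotoxicity, read by crystal violet staining, with a stated time of 96 h; a lower number here means that less compound is tolerated, a higher number that more compound is tolerated:
Compound 1 `CCNC(=S)Nc1cccc(C(F)(F)F)c1`: > 100000 nM (a limit)
Compound 2 `Fc1ccc(NC(=S)Nc2cccc(C(F)(F)F)c2)cc1`: 40000 nM
Compound 3 `CC(=O)NC(=S)Nc1cccc(C(F)(F)F)c1`: > 100000 nM (a limit)

Compound 3 gives only a limit, > 100000 nM. That is the limit of > 100000 nM in this assay, at which 2 of the 3 values shown sit. Compound 4 `C=C(C)CNC(=S)Nc1cccc(C(F)(F)F)c1` carries 2-methylprop-2-en-1-yl in place of acetyl on an amide-type nitrogen. Three measured steps changed this same place. The exchange of ethyl for 4-fluorophenyl gave an at least 2.5-fold lower number from compound 1 to compound 2 (0.39 log units; beyond the scatter), and the exchange of 4-fluorophenyl for acetyl gave an at least 2.5-fold higher number from compound 2 to compound 3 (0.39 log units; beyond the scatter). The exchange of ethyl for acetyl gave a step that the two limits leave unreadable from compound 1 to compound 3. Only compound 2 has a measured number, and neither the group that leaves nor the group that enters here has a ring. A large fall in this assay is therefore not expected, though a modest one cannot be ruled out. The expected change is an at least 1.2-fold lower number from compound 3 to compound 4 (0.09 log units; that floor lies within the scatter), with no clear move beyond the scatter. For compound 4 the estimated value is 80000 nM, with an expected range from 35000 nM to 100000 nM.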

Compound 4, half-maximal cytotoxic concentration: > 100000 nM
Compound 4 gave a limit, no number (the forecaster's own chance of this, stated with the estimate: 55%); middle value at least 1.2-fold (0.09 log units) from the limit.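

In this assay compound 4 gives > 100000 nM, which is a limit and not a number. Among these compounds, the one readable new step is an at least 2.5-fold higher number from compound 2 to compound 4 (0.39 log units; beyond the scatter), and it shows that a 2-methylprop-2-en-1-yl group, with no hydrogen-bond acceptor counted, sits on this amide-type nitrogen as acetyl and ethyl do, while 4-fluorophenyl remains the only group here with a measured number. The other new steps cannot be read, and the three compounds without a ring in this group now share one ceiling: the limit of > 100000 nM in this assay, at which 3 of the 4 values shown sit.

The compounds shown leave open whether the ring or its fluorine goes with the lower number of compound 2, which a plain phenyl or a cyclohexyl group could separate. They also leave open whether a longer chain such as octyl would stay at the limit.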